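The source may report more compounds than this note shows. Statements on the series, on what has been measured and on what is new or still open speak of the compounds shown alone.

Measured so far:

compound 1 `C/C(=C\c1ccc(NC(=O)Nc2ccc(Cl)c(C(F)(F)F)c2)cc1)C(=O)NC(C)c1ccccc1` — > 50000 nM
compound 2 `CC(NC(=O)C#Cc1ccc(NC(=O)Nc2cc(C(F)(F)F)ccc2Cl)cc1)c1ccccc1` — 23200 nM
compound 3 `O=C(/C=C/c1ccc(NC(=O)Nc2ccc(Cl)c(C(F)(F)F)c2)cc1)NC1CCC1` — 17300 nM

In a functional assay on KETR3 cells (Homo sapiens) for inhibition, read by MTT assay, with a stated time of 120 h (a lower number here means a stronger inhibitor, a higher number a weaker inhibitor), compound 3 gives 17300 nM, the lower of the two numbers reported. Compound 2 gives 23200 nM, a gap that lies within the scatter, so the two cannot be ranked against each other. For compound 1 the assay reports only a limit, > 50000 nM (the limit of > 50000 nM in this assay, at which 1 of the 3 values shown sits).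

Compound 4 `CC(NC(=O)/C=C/c1ccc(NC(=O)Nc2ccc(Cl)c(C(F)(F)F)c2)cc1)c1ccccc1` differs from compound 3 by 1-phenylethyl in place of cyclobutyl on an amide-type nitrogen. For the measured compounds named here, no measured pair isolates this change. Compound 2 also carries the 1-phenylethyl group and gives 23200 nM, close to compound 3. Compound 4 is therefore expected to sit near 15000 nM, between 5000 nM and 45000 nM. The expected step of a 1.2-fold lower number from compound 3 to compound 4 (0.06 log units; within the scatter) is estimated to stay within the scatter, in no clear direction.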

Compound 4, half-maximal inhibitory concentration: 21200 nM
The estimate for compound 4 lay 1.4-fold (0.15 log units) below the measured number, within the range that was stated.
By their numbers in this assay, from the lowest: compounds 3, 4 and 2 (each within the scatter of the next). At a limit, above all of these: compound 1.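

In this assay, putting 1-phenylethyl in place of cyclobutyl on the amide-type nitrogen gives a 1.2-fold higher number from compound 3 to compound 4 (0.09 log units; within the scatter). For the compounds shown here, this is the first comparison in the set that differs in one place, and it shows that a six-membered aromatic ring can replace the four-membered ring in this group with no change that can be told from the scatter. No measurement shown here accounts for this result. The compounds shown leave open whether an amine, a carboxylic acid or a longer chain on this amide-type nitrogen would move the number beyond the scatter.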